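One Ring Substituent Swapped, Little Change Expected

A few compounds are considered here, and "the series" means these few. Any claim that something is new, unique, unknown or untested is made for them only; others in the source may bear on it.

Compound 1 `O=C(/C=C/c1ccc2c(c1)B(O)OC2)c1ccccc1` gives 3400 nM in a functional assay on SK-OV-3 cells (Homo sapiens) for cytotoxicity, read by MTT assay, with a stated time of 48 h; a higher number here means a weaker inhibitor, a lower number a stronger inhibitor.
Compound 2 `Cc1ccc(C(=O)/C=C/c2ccc3c(c2)B(O)OC3)cc1` gives 3700 nM in this assay.

Among the compounds with values here, compound 2 and compound 1 cannot be told apart on these numbers: the single measured step, a 1.1-fold higher number from compound 1 to compound 2 (0.04 log units; within the scatter), lies within the scatter, so the two values are effectively the same. Compound 3 `O=C(/C=C/c1ccc2c(c1)B(O)OC2)c1ccccc1O` differs from compound 2 by 2-hydroxyphenyl in place of 4-methylphenyl on a carbonyl carbon. Within the data shown here, the only step that bears on this change is a 1.1-fold higher number from compound 1 to compound 2 (0.04 log units; within the scatter), which shows that altering this same aromatic ring, there by adding a methyl, left the number unchanged. Among the measured compounds shown here, the new change replaces the methyl with a hydroxyl, bringing one hydrogen-bond donor and one acceptor, but no measured pair shows what a hydroxyl does here. The step expected, a 1.1-fold lower number from compound 2 to compound 3 (0.02 log units; within the scatter), is therefore small and within the scatter. Compound 3 is estimated at 3500 nM, with a range from 1500 nM to 8500 nM.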

Compound 3, half-maximal inhibitory concentration: 48800 nM
Beside the measured number, compound 3's estimate is 14-fold (1.14 log units) below it; measured number outside the range, above it.
By their numbers in this assay, from the lowest: compounds 1 and 2 (each within the scatter of the next); then compound 3.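

Unlike the methyl, a hydroxy on this aromatic ring has a large effect: hydroxy in place of hydrogen gives a 14-fold higher number from compound 1 to compound 3 (1.16 log units; beyond the scatter) and 2-hydroxyphenyl in place of 4-methylphenyl gives a 13-fold higher number from compound 2 to compound 3 (1.12 log units; beyond the scatter) in the same assay. A higher number means a weaker inhibitor, so this ring does not tolerate every small change, and compound 3 is clearly weaker than either earlier compound. Nothing available explains why the hydroxy has this effect.

The compounds shown leave open whether the size of this step comes from the hydroxy itself or from where it sits on the ring, since the methyl and the hydroxy carry different numbers in their group names. As far as these compounds go, it also remains open whether a methoxy group or an amine in the hydroxy's place would give a similarly high number.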